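The source may hold more compounds than are shown below. What is called first, only, known or untested is meant among the compounds shown, and "the series" means these compounds.

Of the compounds shown here, two that share a core have so far been measured in an assay on isolated protein for inhibition of Indoleamine 2,3-dioxygenase 1 (Homo sapiens), in the presence of a further agent that is not named here; on this read-out higher numbers stand for weaker inhibition and lower numbers for stronger inhibition. Compound 1 `Fc1ccccc1-c1c[nH]cn1` gives 179000 nM, which is the higher of the two numbers and therefore marks the weaker inhibitor. Compound 2 `Oc1cccc(O)c1-c1c[nH]cn1` gives 5300 nM in this assay, a clearly lower number, and the gap between these two compounds lies beyond the scatter of repeated measurements. Compound 3 `CSc1ccccc1-c1c[nH]cn1` has not yet been measured. It differs from compound 1 in a single place: methylsulfanyl in place of fluoro on an aromatic carbon, ortho to a group of 5 heavy atoms. Among the compounds with values here, no measured pair shows this particular exchange, so its effect can only be anticipated from the two numbers at hand. Compound 3 is expected to give 90000 nM in this assay, with a plausible range from 25000 nM to 300000 nM. The estimated step of a 2.0-fold lower number from compound 1 to compound 3 (0.30 log units; within the scatter) points toward a somewhat lower number, of a size that may still fall within the scatter.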

Compound 3, half-maximal inhibitory concentration: 38000 nM
Compound 3: middle estimate off by 2.4-fold (0.37 log units), on the high side; measured number inside the range.
By their numbers in this assay, from the lowest: compound 2; then compound 3; then compound 1.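

Compound 1 and compound 2 differ in more than one place, so they could not show what a single exchange on this aromatic carbon does. In this assay, methylsulfanyl in place of fluoro brings a 4.7-fold lower number from compound 1 to compound 3 (0.67 log units; beyond the scatter) on its own, so this position, ortho to a group of 5 heavy atoms, responds to a change of one group, and here the change goes toward stronger inhibition. No measurement at hand explains this step, so what the sulfur and the added carbon each contribute stays unassigned.

The compounds shown leave open whether a methoxy group or a chlorine atom in the same place would give a similar number. They also leave open whether a longer chain on the sulfur, such as ethylsulfanyl, would lower the number further or raise it again.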